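The compounds below may be only part of what the source reports. "The series", "measured", "known", "first", "only" and "open" are said of these compounds alone.

Compound 3 `Cc1cc(NC(=O)Cn2nnc(C3CC3)n2)n(C2CCCCC2)n1` is known in an assay on HEK293 cells for activation of Kir3.1/Kir3.2 (Homo sapiens), read by thallium flux (on this read-out lower numbers stand for smaller maximal responses and higher numbers for larger maximal responses), only through a limit, > 68%; this is the limit of > 68% in this assay, at which 1 of the 3 values shown sits, so no number stands for it. The two aryl analogues on the same core are measured as numbers: compound 1 `Cc1cc(NC(=O)Cn2nnc(-c3cccnc3)n2)n(C2CCCCC2)n1` gives 96% in this assay, and compound 2 `Cc1cc(NC(=O)Cn2nnc(-c3ccc(F)c(F)c3)n2)n(C2CCCCC2)n1` gives 93%. The change a number 3 percentage points lower from compound 1 to compound 2 (within the scatter) stays within the scatter. The steps toward compound 3, a step that the limit leaves unreadable from compound 1 to compound 3 and a step that the limit leaves unreadable from compound 2 to compound 3, cannot be sized. Compound 4 `Cc1cc(NC(=O)Cn2nnc(-c3cccc(C#N)c3)n2)n(C2CCCCC2)n1` differs from compound 3 by 3-cyanophenyl in place of cyclopropyl on an aromatic carbon, so it again carries an aromatic ring in the place where compound 1 and compound 2 carry theirs. Since the two measured aryl compounds sit close together and the cyclopropyl compound is known only as a limit, the step that the limit leaves unreadable from compound 3 to compound 4 is expected to return compound 4 to the range of the aryl analogues in this assay. Compound 4 is therefore estimated at 93%, with a range from 80% to 105%.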

Compound 4, largest response reached (Emax), in percent of the reference or control that the assay uses: 80%
For compound 4 the middle estimate is 13 percentage points above the measured one, and the stated range covers the measured number.
By their numbers in this assay, from the lowest: compound 4; then compounds 2 and 1 (each within the scatter of the next).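

In this assay, the aromatic group on this carbon of the five-membered ring now makes a difference, which the pair of pyridin-3-yl and 3,4-difluorophenyl had not shown: a number 3 percentage points lower from compound 1 to compound 2 (within the scatter). With 3-cyanophenyl at the same place, the read-out gives a number 13 percentage points lower from compound 2 to compound 4 (beyond the scatter) and a number 16 percentage points lower from compound 1 to compound 4 (beyond the scatter). Carrying an aromatic ring here is therefore not enough to fix the maximal response among these three aryl compounds, although the steps remain modest. Compound 3 is known only as a limit, so neither its step to compound 4 nor any ranking against the aryl compounds can be read: the limit of > 68% in this assay, at which 1 of the 4 values shown sits.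

From the compounds shown here alone, it remains open whether the nitrile itself accounts for the lower response of compound 4, or whether the phenyl ring it sits on plays a part. Going by these compounds, how a carboxylic acid or an amine in place of the nitrile would fare also remains open.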